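This account rests on a few compounds, and the source may have more. Where it says the series, first, only, none or still open, it means among the compounds named here.

Compound 1 `COc1ccc(Br)cc1-c1cc(CO)on1`, which carries a hydroxymethyl group, gives > 200000 nM in a functional assay on BV-2 cells (Mus musculus) for inhibition, read by Griess assay, with a stated time of 24 h (a higher number here means a weaker inhibitor, a lower number a stronger inhibitor), and this is a limit, not a number. Compound 2 `C=CCc1ccc(OC)c(-c2cc(CCC)on2)c1` gives > 200000 nM in this assay, which is also a limit. Compound 3 `C=CCc1ccc(OC)c(-c2cc(CO)on2)c1` differs from compound 2 in one place: hydroxy in place of ethyl on a saturated chain carbon bound to an aromatic carbon. In words, hydroxy stands in place of ethyl on a saturated chain carbon bound to an aromatic carbon, turning propyl into hydroxymethyl. In this assay the estimated step of an at least 1.3-fold lower number from compound 2 to compound 3 (0.12 log units; that floor lies within the scatter) is expected to be small, toward stronger inhibition. Compound 3 is expected at about 150000 nM, with an estimated range from 50000 nM to 300000 nM.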

Compound 3, half-maximal inhibitory concentration: > 200000 nM
Compound 3: a limit, no number; the forecaster's own chance of this, stated with the estimate: 60%; middle value at least 1.3-fold (0.12 log units) away from the limit.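

Among the compounds shown here, compound 1, compound 2 and compound 3 all stop at the same limit, so no step between them can be read: the limit of > 200000 nM in this assay, at which 3 of the 3 values shown sit. As far as these compounds go, how far each compound lies past that limit in this assay stays open, and with it whether swapping propyl for hydroxymethyl changes anything.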